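A Fluoromethyl Chain in Place of a Methoxymethyl Chain

This account rests on a few compounds, and the source may have more. Where it says the series, first, only, none or still open, it means among the compounds named here.

Three compounds sharing one core were measured in a functional assay on HL-60 cells (Homo sapiens) for cytotoxicity, read by WST assay, with a stated time of 48 h; on this read-out higher numbers stand for weaker inhibition and lower numbers for stronger inhibition. Compound 3 `COC[C@@H](C(C)C)C(c1ccc(O)c(OC)c1)c1ccc(O)c(OC)c1` gives 54000 nM, the second highest of the three numbers; compound 1 `COC[C@H](C)[C@H](C)C(c1ccc(O)c(OC)c1)c1ccc(O)c(OC)c1` gives 82000 nM, and a 1.5-fold lower number from compound 1 to compound 3 (0.18 log units; within the scatter) lies within the scatter, whereas compound 2 `COc1cc(C(c2ccc(O)c(OC)c2)[C@H](C)C(C)C)ccc1O` gives 17000 nM, with a 3.2-fold higher number from compound 2 to compound 3 (0.50 log units; beyond the scatter) beyond it. Compound 4 `COc1cc(C(c2ccc(O)c(OC)c2)[C@H](C)[C@@H](C)CF)ccc1O` differs from compound 3 in one place: 2-(fluoromethyl)-1-methylpropyl in place of 1-(methoxymethyl)-2-methylpropyl on a saturated chain carbon bound to two aromatic carbons. Within the data shown here, the steps that bear on this change are a 4.8-fold lower number from compound 1 to compound 2 (0.68 log units; beyond the scatter) and a 3.2-fold higher number from compound 2 to compound 3 (0.50 log units; beyond the scatter), both modest, and the flat a 1.5-fold lower number from compound 1 to compound 3 (0.18 log units; within the scatter). Compound 2, which also carries no hydrogen-bond acceptor on its chain, gives 17000 nM, so for compound 4 a modest downward step is expected, a 1.8-fold lower number from compound 3 to compound 4 (0.26 log units; within the scatter). Compound 4 is therefore estimated at 30000 nM, within 12000 nM to 75000 nM.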

Compound 4, half-maximal inhibitory concentration: 45000 nM
Estimate against measurement, compound 4: 1.5-fold (0.18 log units) below, within the range that was stated.
By their numbers in this assay, from the lowest: compound 2; then compounds 4, 3 and 1 (each within the scatter of the next).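

Putting 2-(fluoromethyl)-1-methylpropyl in place of 1-(methoxymethyl)-2-methylpropyl on this saturated chain carbon leaves the number within the scatter (a 1.2-fold lower number from compound 3 to compound 4 (0.08 log units; within the scatter)), and the same holds against the 2-(methoxymethyl)-1-methylpropyl chain (a 1.8-fold lower number from compound 1 to compound 4 (0.26 log units; within the scatter)). Fluoro in place of hydrogen, by contrast, gives a step beyond the scatter (a 2.6-fold higher number from compound 2 to compound 4 (0.42 log units; beyond the scatter)), so a chain with no hydrogen-bond acceptor does not by that alone match compound 2. No measurement here accounts for these steps. The compounds shown leave open how a chain ending in an amine or a carboxylic acid, or a longer chain, would read at this place.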